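A few compounds are considered here, and "the series" means these few. Any claim that something is new, unique, unknown or untested is made for them only; others in the source may bear on it.

In a functional assay on MCF7 cells (Homo sapiens) for antiproliferative activity, read by sulforhodamine B assay, with a stated time of 48 h (a lower number here means a stronger inhibitor, a higher number a weaker inhibitor), compound 1 `O=C1NCCN1c1ccc(S(=O)(=O)Nc2ccc(F)c(F)c2)cc1` gives 620 nM, compound 2 `CCc1cccc(NS(=O)(=O)c2ccc(N3CCNC3=O)cc2)c1` gives 130 nM, and compound 3 `O=C1NCCN1c1ccc(S(=O)(=O)Nc2ccc(Cl)cc2)cc1` gives 170 nM. Compound 3 therefore stands within the scatter of compound 2 and clearly apart from compound 1. Compound 4 `O=C1NCCN1c1ccc(S(=O)(=O)Nc2ccc(Br)cc2)cc1` differs from compound 3 by a single exchange: bromo in place of chloro on an aromatic carbon, para to a large group. For the measured compounds named here, no measured step makes this exact exchange. Going by the values given here, the steps that bear on it all alter the group on the sulfonamide nitrogen: a 3.6-fold lower number from compound 1 to compound 3 (0.56 log units; beyond the scatter) and a 4.8-fold lower number from compound 1 to compound 2 (0.68 log units; beyond the scatter) are modest, while a 1.3-fold higher number from compound 2 to compound 3 (0.12 log units; within the scatter) stays within the scatter. No step beyond the scatter is therefore expected in this assay. The expected step is a 1.1-fold lower number from compound 3 to compound 4 (0.03 log units; within the scatter). Compound 4 is estimated at 160 nM, with an expected range of 70 nM to 350 nM.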

Compound 4, half-maximal inhibitory concentration: 240 nM
Estimate against measurement, compound 4: 1.5-fold (0.18 log units) below; low and high end bracket the measured number.
By their numbers in this assay, from the lowest: compounds 2, 3 and 4 (each within the scatter of the next); then compound 1.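

In this assay, the exchange of chloro for bromo on this aromatic carbon, the first direct test of this change, stays within the scatter (a 1.4-fold higher number from compound 3 to compound 4 (0.15 log units; within the scatter)). The 4-bromophenyl group likewise stays within the scatter of 3-ethylphenyl (a 1.8-fold higher number from compound 2 to compound 4 (0.27 log units; within the scatter)), yet stands apart from 3,4-difluorophenyl (a 2.6-fold lower number from compound 1 to compound 4 (0.41 log units; beyond the scatter)). No evidence at hand accounts for these results. The compounds shown leave open whether an amine, a carboxylic acid or a longer chain on this carbon would keep the number in the same range.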